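Ester cleavage in a small set of cytotoxicity compounds

A few compounds are considered here, and "the series" means these few. Any claim that something is new, unique, unknown or untested is made for them only; others in the source may bear on it.

Measured in a functional assay on ECV-304 cells (Homo sapiens) for cytotoxicity, read by MTT assay, with stated times of 24 h and 12 h; on this read-out lower numbers stand for an effect already at smaller amounts and higher numbers for an effect only at larger amounts of compound:
Compound 1 `CCOC(=O)/C=C/c1ccc(OCc2nc(C)c(C)nc2C)c(O)c1`: 139000 nM
Compound 2 `CCOC(=O)/C=C/c1cccc(OCc2nc(C)c(C)nc2C)c1`: 4330000 nM
Compound 3 `Cc1nc(C)c(COc2ccc(/C=C/C(=O)O)cc2O)nc1C`: 46000 nM

Compound 3 differs from compound 1 by hydrogen in place of ethyl on an oxygen next to a carbonyl group, and this change gave a 3.0-fold lower number from compound 1 to compound 3 (0.48 log units; beyond the scatter) in this assay. Compound 2 carries the same ester as compound 1 on a different core; how the two cores differ is not broken down here, and compound 2 stands highest of the three numbers. Compound 4 `Cc1nc(C)c(COc2cccc(/C=C/C(=O)O)c2)nc1C` is to be measured; it differs from compound 2 by hydrogen in place of ethyl on an oxygen next to a carbonyl group, at a place described in exactly the same words as for compound 1 and compound 3, so it is the same change. In this assay, for the measured compounds named here, a step of a 3.0-fold lower number from compound 2 to compound 4 (0.48 log units; beyond the scatter) from compound 2 to compound 4 is expected, because a 3.0-fold lower number from compound 1 to compound 3 (0.48 log units; beyond the scatter) is the only measured instance of this change. Compound 4 is therefore estimated at 1440000 nM, between 500000 nM and 4000000 nM.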

Compound 4, half-maximal effective concentration: 20000 nM
Beside the measured number, compound 4's estimate is 72-fold (1.86 log units) above it; measured number below the stated range.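

In this assay the change from ethoxycarbonyl to carboxy gave a 220-fold lower number from compound 2 to compound 4 (2.34 log units; beyond the scatter) and so went in the same direction on both cores, but its size did not carry over from one core to the other: the same change on two cores in this assay, a 3.0-fold lower number (0.48 log units; beyond the scatter) from compound 1 to compound 3 and a 220-fold lower number (2.34 log units; beyond the scatter) from compound 2 to compound 4, 72-fold (1.86 log units) apart, beyond the scatter of two such steps. The number fell with this change on each core, yet two instances give no rule for the size of the step on a further core. Nor do they show which feature of the cores sets that size.

The compounds shown leave open whether a methyl ester or an amide at the same place would stand with the ethoxycarbonyl compounds or with the carboxy compounds.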